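A few compounds are considered here, and "the series" means these few. Any claim that something is new, unique, unknown or untested is made for them only; others in the source may bear on it.

Two members of the series carry a number in an ADME assay on HEK293 cells for displacement of a labelled ligand from 5-hydroxytryptamine receptor 6 (Homo sapiens), read by radioligand binding, with a stated time of 1 h (a higher number here means a weaker inhibitor, a lower number a stronger inhibitor), so far. Compound 1, `O=C1c2ccccc2S(=O)(=O)N1CCCCCCN1CCN(c2cccc(Cl)c2)CC1`, gives 372 nM, and compound 2, `O=C1c2ccccc2S(=O)(=O)N1CCCCCCN1CCN(c2cccc(C(F)(F)F)c2)CC1`, gives 52 nM. Among the compounds with values here, the one step between them, trifluoromethyl in place of chloro on an aromatic carbon, is a 7.2-fold lower number from compound 1 to compound 2 (0.85 log units; beyond the scatter). Compound 2 therefore stands at the low end of the two numbers shown, with compound 1 the only neighbour, a higher number beyond the scatter.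

Compound 3, `O=C1c2ccccc2S(=O)(=O)N1CCCCCCN1CCN(c2ccccc2)CC1`, has not yet been measured. It differs from compound 2 in one place: hydrogen in place of trifluoromethyl on an aromatic carbon, cut one bond further out 3-(trifluoromethyl)phenyl to phenyl. Within the data shown here, the only measured step that bears on this position is the chloro-to-trifluoromethyl change, which moved the number by a 7.2-fold lower number from compound 1 to compound 2 (0.85 log units; beyond the scatter); a smaller substituent at the same position went with the higher number. Removing the substituent altogether is expected to move the number up again, by more than that step, because the move from compound 1 to compound 2 a 7.2-fold lower number from compound 1 to compound 2 (0.85 log units; beyond the scatter) already points in that direction. For compound 3 the expected step is a 15-fold higher number from compound 2 to compound 3 (1.19 log units; beyond the scatter). Compound 3 is estimated at 800 nM, within a range from 250 nM to 2500 nM.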

Compound 3, inhibition constant: 971 nM
Estimate against measurement, compound 3: 1.2-fold (0.08 log units) below, within the range that was stated.
By their numbers in this assay, from the lowest: compound 2; then compound 1; then compound 3.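

With hydrogen on this aromatic carbon, the series now has an unsubstituted reference in this assay, and both earlier substituents can be read against it: losing trifluoromethyl gives a 19-fold higher number from compound 2 to compound 3 (1.27 log units; beyond the scatter) and losing chloro gives a 2.6-fold higher number from compound 1 to compound 3 (0.42 log units; beyond the scatter) on the same core. Chloro and trifluoromethyl therefore both go with a lower number than hydrogen, so the earlier chloro-to-trifluoromethyl step was a difference between two favourable substituents, and most of the gain seen with trifluoromethyl over hydrogen lies beyond what chloro provides. Nothing among the data on hand accounts for these differences, and the ranking rests on just these three compounds.

The compounds shown leave open whether the same order would hold for other groups at this place, such as a methoxy group, a nitrile, an amine or a carboxylic acid, or for trifluoromethyl placed elsewhere on the ring. They also leave open whether the steps seen here would keep their direction and size with a shorter or longer chain joining the piperazine-bearing end to the shared core.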